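A few compounds are considered here, and "the series" means these few. Any claim that something is new, unique, unknown or untested is made for them only; others in the source may bear on it.

Measured so far:
Compound 1, `O=C(O)c1ccc(NCc2cccc(Oc3ccccc3)c2)cc1`: in a functional assay on CHO cells for agonist activity at Free fatty acid receptor 1 (Homo sapiens) (a higher number here means that more compound is needed for the effect, a lower number that less compound is needed), compound 1 reaches only a limit, < 10000 nM.
Compound 2, `Cc1nc(-c2ccc(C(F)(F)F)cc2)sc1CNc1ccc(/C=C/C(=O)O)cc1`: in this assay compound 2 gives 36.3 nM.

Among the compounds with values here, compound 2 thus holds the only numerical value in this assay; the other entry is a limit of the assay, (the limit of < 10000 nM in this assay, at which 1 of the 2 values shown sits). Within the data shown here, since no two measured compounds differ in a single place, no measured step is available to calibrate the change that follows.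

Compound 3, `Cc1nc(-c2ccc(C(F)(F)F)cc2)sc1CNc1ccc([C@H]2C[C@@H]2C(N)=O)cc1`, has not yet been measured. It differs from compound 2 in one place: 2-carbamoylcyclopropyl in place of 2-carboxyethenyl on an aromatic carbon. Among the measured compounds shown here, with no measured step to lean on, the expectation rests on the structural change alone. The step is expected to go beyond the scatter, toward higher values: a 17-fold higher number from compound 2 to compound 3 (1.22 log units; beyond the scatter). For compound 3 the estimate in this assay is 600 nM, with a range from 100 nM to 4000 nM.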

Compound 3, half-maximal effective concentration: 4.47 nM
Estimate against measurement, compound 3: 130-fold (2.13 log units) above; measured number below the stated range.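

Within the data shown here, exchanging the 2-carboxyethenyl group for a 2-carbamoylcyclopropyl group, para to a large group, gives in this assay an 8.1-fold lower number from compound 2 to compound 3 (0.91 log units; beyond the scatter) and so supplies the first measured step. The position therefore accepts a group without a carboxylic acid, carrying a three-membered ring and two defined stereocentres, and the number does not rise but falls beyond the scatter. Nothing measured here gives a reason for this fall.

The exchange replaces the carboxylic acid with an amide and the ethenyl link with a three-membered ring in a single step, and the compounds shown do not separate these two changes. On these data alone, it remains open how a 2-carboxycyclopropyl group, a 2-carbamoylethenyl group or the opposite arrangement at the two stereocentres would behave at this position.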